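A few compounds are considered here, and "the series" means these few. Any claim that something is new, unique, unknown or untested is made for them only; others in the source may bear on it.

- compound 1 `Cc1ccc(C(=O)Nc2cccc(C(F)(F)F)c2)cc1-c1ccc2c(-c3cnn(C(C)C)c3)n[nH]c2c1`: 452 nM
- compound 2 `Cc1ccc(C(=O)Nc2cccc(C(F)(F)F)c2)cc1-c1ccc2c(-c3cnn(CC(C)O)c3)n[nH]c2c1`: 339 nM

In a functional assay on KG-1 cells (Homo sapiens) for antiproliferative activity, read by CCK-8 assay, with a stated time of 72 h (on this read-out higher numbers stand for weaker inhibition and lower numbers for stronger inhibition), compound 2 gives 339 nM, the lower of just two numbers, but the gap is small. The measured change is a 1.3-fold lower number from compound 1 to compound 2 (0.12 log units; within the scatter), so the two compounds cannot be ranked against each other.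

The next compound, compound 3 `Cc1ccc(C(=O)Nc2cccc(C(F)(F)F)c2)cc1-c1ccc2c(-c3cnn(C4CCN(C)CC4)c3)n[nH]c2c1`, keeps the shared core and changes only the group on the aromatic nitrogen: 1-methylpiperidin-4-yl in place of 2-hydroxypropyl on an aromatic nitrogen. In words, 1-methylpiperidin-4-yl stands in place of 2-hydroxypropyl.

Among the measured compounds shown here, only one measured step bears on this change, a 1.3-fold lower number from compound 1 to compound 2 (0.12 log units; within the scatter), and it stayed within the scatter. That step gives no reason to expect a large shift in this assay, so no change beyond the scatter is the working expectation. Going by these compounds, it is weak evidence, however: neither compound 1 nor compound 2 carries a ring at this place, so the new group is untested here and the range must stay wide.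

The expected step is a 1.3-fold lower number from compound 2 to compound 3 (0.12 log units; within the scatter). For compound 3, the estimated value is 260 nM, with an expected range of 80 nM to 850 nM.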

Compound 3, half-maximal inhibitory concentration: 93.3 nM
The estimate for compound 3 lay 2.8-fold (0.45 log units) above the measured number, within the range that was stated.
By their numbers in this assay, from the lowest: compound 3; then compounds 2 and 1 (each within the scatter of the next).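

In this assay, the group on the aromatic nitrogen does make a difference: 1-methylpiperidin-4-yl in place of 2-hydroxypropyl gives a 3.6-fold lower number from compound 2 to compound 3 (0.56 log units; beyond the scatter), and in place of isopropyl it gives a 4.8-fold lower number from compound 1 to compound 3 (0.69 log units; beyond the scatter). Among the compounds shown here, both steps are modest, but they are the first at this place to lie beyond the scatter, and the new group stands apart from both earlier groups, which could not be ranked against each other. The swap from 2-hydroxypropyl changes several things at once, bringing in a six-membered non-aromatic ring, a ring nitrogen and more heavy atoms while removing the hydrogen-bond donor, and nothing measured here explains why the number falls.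

The compounds shown leave open whether the lower number goes with the ring or with its nitrogen: a cyclohexyl group has the ring without the nitrogen, and an open chain ending in a dimethylamino group has the nitrogen without the ring. Also open, going by these compounds, is what the methyl group contributes, which the unsubstituted piperidin-4-yl group would test.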